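The source may report more compounds than this note shows. Statements on the series, on what has been measured and on what is new or still open speak of the compounds shown alone.

Measured compounds:
Compound 1, `Nc1nc(Cl)c2ncn(Cc3ccc(CCl)cc3)c2n1`: 31000 nM
Compound 2, `ClCc1cccc(Cn2cnc3c(Cl)nc(Cl)nc32)c1`: 3020 nM
Compound 3, `ClCc1ccc(Cn2cnc3c(Cl)nc(Cl)nc32)cc1`: 19100 nM

The three measured compounds were all tested in a functional assay on SK-MEL-5 cells (Homo sapiens) for cytotoxicity, read by sulforhodamine B assay, with a stated time of 48 h; a higher number here means a weaker inhibitor of growth, a lower number a stronger inhibitor of growth. Compound 2 gives the lowest of the three numbers in this assay, with 3020 nM. Compound 3 stands closer to it than compound 1 does; in this assay compound 3 gives 19100 nM, and compound 1 gives 31000 nM. Compound 2 and compound 3 are built from the same atoms joined differently, and the difference between their two cores is not broken down here.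

Compound 3 and compound 1 differ in one place: amino in place of chloro on an aromatic carbon. That change made a step of a 1.6-fold higher number from compound 3 to compound 1 (0.21 log units; within the scatter).

The unmeasured compound 4, `Nc1nc(Cl)c2ncn(Cc3cccc(CCl)c3)c2n1`, relates to compound 2 in the same way: amino in place of chloro on an aromatic carbon. The surroundings of the changed carbon are described in the same words for both pairs, so this is the same change, now made on the core of compound 2 rather than that of compound 3.

Because the earlier step was a 1.6-fold higher number from compound 3 to compound 1 (0.21 log units; within the scatter), compound 4 is expected to land near compound 2, with an estimated step of a 1.6-fold higher number from compound 2 to compound 4 (0.20 log units; within the scatter). In this assay compound 4 is therefore expected to give about 4800 nM, plausibly between 2000 nM and 12000 nM. This rests on a single earlier example of the change, so the expectation is held loosely.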

Compound 4, concentration for total growth inhibition: 23400 nM
The estimate for compound 4 lay 4.9-fold (0.69 log units) below the measured number; measured number above the stated range.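

In this assay, putting amino in place of chloro on the aromatic carbon between two ring nitrogen atoms gave a step of a 7.7-fold higher number from compound 2 to compound 4 (0.89 log units; beyond the scatter), so on this core the change clearly weakened growth inhibition. Among these compounds, the size of the step did not carry over from the other core: the same change on two cores in this assay, a 1.6-fold higher number (0.21 log units; within the scatter) from compound 3 to compound 1 and a 7.7-fold higher number (0.89 log units; beyond the scatter) from compound 2 to compound 4, 4.8-fold (0.68 log units) apart, beyond the scatter of two such steps This shows that, in these two pairs, the effect of the change depended on the core it was made on, so a step read on one core was a poor guide to the other, but with only two pairs it gives no general rule for the series and does not explain why the two steps differ.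

All the compounds shown carry either chloro or amino at this carbon, so it remains open how a methoxy group, a methylamino group or a longer amine chain would behave there, and whether either core would again give a different step. All of them also keep the chloromethyl group, which leaves open whether the gap between the two steps would persist if a hydroxymethyl or a plain methyl group stood in its place.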